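A few compounds are considered here, and "the series" means these few. Any claim that something is new, unique, unknown or untested is made for them only; others in the source may bear on it.

Working notes on the series. Compound 2 `COc1ccccc1/C=C/C(=O)/C=C/C1=C(C)CCCC1(C)C` gives 88200 nM in a functional assay on HeLa cells (Homo sapiens) for cytotoxicity, read by sulforhodamine B assay, with a stated time of 48 h; on this read-out lower numbers stand for stronger inhibition and higher numbers for weaker inhibition; of the two numbers shown it is the larger, though its only neighbour, compound 1 `CC1=C(/C=C/C(=O)/C=C/c2ccccc2)C(C)(C)CCC1` with 70200 nM, sits so close that the step of a 1.3-fold higher number from compound 1 to compound 2 (0.10 log units; within the scatter) stays within the scatter. Compound 3 `CC1=C(/C=C/C(=O)/C=C/c2ccccc2[N+](=O)[O-])C(C)(C)CCC1` has not yet been run. It differs from compound 2 by nitro in place of methoxy on an aromatic carbon. Among the compounds with values here, the one measured step that bears on this position is a 1.3-fold higher number from compound 1 to compound 2 (0.10 log units; within the scatter), which put a methoxy in place of hydrogen on that aromatic carbon and moved the number by no more than the scatter allows. Within the data shown here, no measured pair exchanges a methoxy for a nitro, so the nitro itself is untested here. On this basis compound 3 is expected to move by a 1.1-fold lower number from compound 2 to compound 3 (0.04 log units; within the scatter), that is, no step beyond the scatter in this assay. The estimate for compound 3 is 80000 nM, with a range from 30000 nM to 200000 nM.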

Compound 3, half-maximal inhibitory concentration: 36100 nM
Beside the measured number, compound 3's estimate is 2.2-fold (0.35 log units) above it; the measured number falls inside the stated range.
By their numbers in this assay, from the lowest: compounds 3, 1 and 2 (each within the scatter of the next, the first and the last beyond it).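

Within the data shown here, at the aromatic carbon ortho to a large group, the choice of substituent now shows a measurable effect in this assay: exchanging methoxy for nitro gives a 2.4-fold lower number from compound 2 to compound 3 (0.39 log units; beyond the scatter), the first step beyond the scatter. Against hydrogen the same nitro gives a 1.9-fold lower number from compound 1 to compound 3 (0.29 log units; within the scatter), so the series separates the nitro and methoxy compounds but does not separate either of them from the unsubstituted compound 1. Nothing measured here accounts for the step between methoxy and nitro.

From the compounds shown here alone, whether this position tolerates other groups remains open, as an amine, a carboxylic acid or a chlorine atom at the same carbon would show how far the values spread. Also open, going by these compounds, is whether nitro on another carbon of the ring gives a similar value.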